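This account rests on a few compounds, and the source may have more. Where it says the series, first, only, none or still open, it means among the compounds named here.

Measured so far, in a functional assay on the whole organism for inhibition, with Rattus norvegicus as the target; a lower number here means that less compound is needed, a higher number that more compound is needed for the effect:

compound 1 `C[C@H]1CCC(=NNc2ccccc2)c2ncc(C(=O)O)c(=O)n21` gives 0.3 umol/kg; 54.8 umol/kg (2 entries)
compound 2 `CC1CC/C(=N\Nc2cccc([N+](=O)[O-])c2)c2ncc(C(=O)O)c(=O)n21` gives 0.5 umol/kg
compound 3 `CC1CC/C(=N\Nc2ccc([N+](=O)[O-])cc2)c2ncc(C(=O)O)c(=O)n21` gives 0.8 umol/kg

Compound 3 has the higher of the two single numbers in this assay, but its nearest neighbour, compound 2, lies within the scatter of it, so the two cannot be told apart. Compound 1 does not give a single number, as shown by the several entries of compound 1 in this assay, 0.3 umol/kg; 54.8 umol/kg (2 entries), and no step between compound 1 and the other two can be drawn. Among the compounds with values here, no step between two measured compounds is available for this series.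

The next compound is compound 4 `CNC(=O)c1ccc(N/N=C2\CCC(C)n3c2ncc(C(=O)O)c3=O)cc1`. It differs from compound 3 in one place: methylcarbamoyl in place of nitro on an aromatic carbon. The two nitro isomers, compound 2 and compound 3, sit within the scatter of each other, and the unsubstituted phenyl of compound 1 has one entry of a similar size, so the ring substituent has so far not moved the number beyond the scatter. For compound 4 the step of no change at the digits printed from compound 3 to compound 4 (within the scatter) is therefore expected to stay within the scatter, with no clear direction.

Compound 4 is estimated at 0.8 umol/kg in this assay, with a range from 0.25 umol/kg to 2.5 umol/kg.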

Compound 4, dose for 50% inhibition: 9.6 umol/kg
Compound 4: the middle estimate sits 12-fold (1.08 log units) below what was measured; the whole stated range lies below it.
By their numbers in this assay, from the lowest: compounds 2 and 3 (each within the scatter of the next); then compound 4.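

In this assay, the aromatic carbon para to a large group proves sensitive to what it carries, with methylcarbamoyl in place of nitro giving a 12-fold higher number from compound 3 to compound 4 (1.08 log units; beyond the scatter). Among the single numbers, this is the first change to a ring substituent that reaches beyond the scatter, since the two nitro isomers, compound 2 and compound 3, could not be told apart. The counted differences are modest: the entering group is slightly larger and carries a hydrogen-bond donor that nitro lacks, neither group has a net charge, and this one step cannot tie the higher number to any of these differences.

From the compounds shown here alone, it remains open whether the higher number belongs to the amide as such, to its methyl or to its hydrogen, and an unsubstituted carboxamide, a dimethylamide, an amine or a carboxylic acid on this carbon would be needed to separate these readings. How methylcarbamoyl compares with the unsubstituted phenyl also cannot be read, because compound 1 has no single number: the several entries of compound 1 in this assay, 0.3 umol/kg; 54.8 umol/kg (2 entries)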